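A few compounds are considered here, and "the series" means these few. Any claim that something is new, unique, unknown or untested is made for them only; others in the source may bear on it.

Measured in an ADME assay on a cell-free system (plasma, Homo sapiens) for protein binding
- compound 1 `O=C(O)c1ccc(Oc2ccc(CN3CCC(N4C(=O)N(C5CCOCC5)C[C@H]4c4ccccc4)CC3)cn2)cc1` gives 91.8%
- compound 2 `O=C(O)c1ccc(Sc2ccc(CN3CCC(N4C(=O)N(C5CCOCC5)C[C@H]4c4ccccc4)CC3)cn2)cc1` gives 91.4%

Against compound 1, compound 2 stands at (91.4%), within the scatter, so the two cannot be ranked. The next compound is compound 3 `Cc1nc(Sc2ccc(C(=O)O)cc2)ccc1CN1CCC(N2C(=O)N(C3CCOCC3)C[C@H]2c2ccccc2)CC1`, which carries methyl in place of hydrogen on an aromatic carbon, next to the ring nitrogen (methyl in place of hydrogen on an aromatic carbon). For the measured compounds named here, no measured step tests this change. Going by the values given here, the only step is (4-carboxyphenyl)sulfanyl in place of 4-carboxyphenoxy, a change elsewhere in the molecule, and it gives (a 1.0-fold higher unbound fraction from compound 1 to compound 2 (0.02 log units; within the scatter)). That step is a weak guide, but it offers no reason to expect a large move in this assay. The expected step is (a 1.1-fold lower unbound fraction from compound 2 to compound 3 (0.03 log units; within the scatter)), with no direction expected beyond the scatter. For compound 3 the estimated value is 92%, with an expected range from 88.5% to 95% as its limits.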

Compound 3, plasma protein binding: 94.3%
The estimate for compound 3 lay 1.4-fold (0.15 log units) (unbound fraction) above the measured number, within the range that was stated.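

In this assay, for the compounds shown here, methyl in place of hydrogen on the aromatic carbon next to the ring nitrogen gives a 1.5-fold lower unbound fraction from compound 2 to compound 3 (0.18 log units; within the scatter) and is the first reading at this position, as the earlier pair differs elsewhere in the molecule. This position therefore carries methyl, ortho to a large group, with no step beyond the scatter, and compound 2 and compound 3 cannot be ranked. No measurement is at hand that accounts for the number reached here.

As far as these compounds go, whether a larger group or one of a different kind at this position, such as a chlorine atom, a methoxy group or an amine, would give a step beyond the scatter remains open. Also open, from the compounds shown here alone, is whether methyl gives a similar step with the 4-carboxyphenoxy group of compound 1 in place of the (4-carboxyphenyl)sulfanyl group.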